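Trimming the pyridine substituent of compound 2

A few compounds are considered here, and "the series" means these few. Any claim that something is new, unique, unknown or untested is made for them only; others in the source may bear on it.

Three compounds share the same core, an acetic acid on a thiazole carrying two aryl groups. Compound 1 `O=C(O)Cc1sc(COc2ccc(Cl)cc2)nc1-c1ccc(Cl)cc1` gives 32 nM in an in vitro assay on HEK385-7 cells for displacement of a labelled ligand from prostaglandin D2 receptor 2 (Homo sapiens) (on this read-out higher numbers stand for weaker inhibition and lower numbers for stronger inhibition), compound 3 `O=C(O)Cc1sc(C(c2ccccc2)c2ccccc2)nc1-c1cccc(F)c1` gives 2.9 nM, and compound 2 `O=C(O)Cc1sc(C(c2ccc(F)cc2)c2ccc(F)cc2)nc1-c1ccnc(N2CCC2)c1` gives 660 nM. Compound 2 thus stands highest of the three; its nearest neighbour is compound 1, and the gap between them, like the larger gap to compound 3, lies beyond the usual scatter.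

Compound 4 `Cc1cc(-c2nc(C(c3ccc(F)cc3)c3ccc(F)cc3)sc2CC(=O)O)ccn1` is not yet measured. It differs from compound 2 in one place: methyl in place of azetidin-1-yl on an aromatic carbon, so that 2-(azetidin-1-yl)pyridin-4-yl becomes 2-methylpyridin-4-yl. Among the compounds with values here, no measured pair shows this exact change, so no step between measured compounds can be quoted for it.

Because compound 3 reaches 2.9 nM with a plain aryl ring at that position, a smaller group on the pyridine is expected to move the number down rather than up, by a step beyond the scatter. The expected step is a 3.3-fold lower number from compound 2 to compound 4 (0.52 log units; beyond the scatter). Compound 4 is therefore estimated at 200 nM, within a range from 40 nM to 1000 nM.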

Compound 4, half-maximal inhibitory concentration: 3.1 nM
Estimate against measurement, compound 4: 65-fold (1.81 log units) above, outside the stated range (below it).
By their numbers in this assay, from the lowest: compounds 3 and 4 (each within the scatter of the next); then compound 1; then compound 2.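

In this assay, methyl in place of azetidin-1-yl on an aromatic carbon, next to the ring nitrogen, brings a 210-fold lower number from compound 2 to compound 4 (2.33 log units; beyond the scatter), with the rest of the molecule unchanged. Within the data shown here, the earlier compounds differ from one another in more than one place, so only this pair ties the high number of compound 2 to the 2-(azetidin-1-yl)pyridin-4-yl group and shows how strongly the number depends on what this position carries. Nothing at hand gives a measured reason for a step of this size.

Going by these compounds, it remains open whether an open-chain amine such as dimethylamino would behave like azetidin-1-yl or like methyl, and where ethyl, methoxy or plain hydrogen would fall at this position. On these data alone, it is also open whether the same change would give a similar step with other groups in place of the two 4-fluorophenyl rings.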